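The source may report more compounds than this note shows. Statements on the series, on what has been measured and on what is new or still open speak of the compounds shown alone.

Compound 1 `Cn1c(-c2ccccc2C(F)(F)F)nnc1C12CCC(CCS(=O)(=O)C(C)(C)C)(CC1)CC2`: > 4000 nM
Compound 2 `CCS(=O)(=O)CCC12CCC(c3nnc(-c4ccccc4C)n3C)(CC1)CC2`: > 4000 nM
Compound 3 `Cn1c(-c2ccccc2C(F)(F)F)nnc1C12CCC(CNS(C)(=O)=O)(CC1)CC2`: > 4000 nM

In an assay on CHO-K1 cells for inhibition of 11-beta-hydroxysteroid dehydrogenase type 2 (Mus musculus), read by scintillation proximity assay (on this read-out higher numbers stand for weaker inhibition and lower numbers for stronger inhibition), compound 1 reaches only the limit of the assay, > 4000 nM. In this assay compound 2 likewise gives a limit, > 4000 nM. Compound 3 also gives a limit in this assay, > 4000 nM, so where it stands can be said only as one of three compounds that all rest at this limit (the limit of > 4000 nM in this assay, at which 3 of the 3 values shown sit). For the measured compounds named here, the single measured step, a step that the two limits leave unreadable from compound 1 to compound 3, joins two limits and so shows neither a size nor a direction.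

Compound 4 `CCS(=O)(=O)CCCCC12CCC(c3nnc(-c4ccccc4C(F)(F)F)n3C)(CC1)CC2` is not yet measured. It differs from compound 3 in one place: 3-(ethylsulfonyl)propyl in place of methanesulfonamido on a saturated chain carbon bound to a saturated ring carbon. Going by the values given here, the only step that bears on this change is a step that the two limits leave unreadable from compound 1 to compound 3, which alters the same chain carbon but gives no readable size. Among the compounds with values here, with every value shown resting at the limit (the limit of > 4000 nM in this assay, at which 3 of the 3 values shown sit), no step of known size exists from which to project. The step from compound 3 to compound 4 is therefore expected to be a step that the limit leaves unreadable from compound 3 to compound 4, meaning that compound 4 is expected most likely to remain beyond the limit as well. Compound 4 is estimated at 6000 nM in this assay, with a range from 1500 nM to 25000 nM.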

Compound 4, half-maximal inhibitory concentration: > 4000 nM
Compound 4 was reported as a limit; the forecaster's own chance of this, stated with the estimate: 80%; the middle value is on the limit's open side.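

Compound 4 is also reported only as a limit, so its steps from compound 3 and from compound 1 join one limit to another and cannot be read: the limit of > 4000 nM in this assay, at which 4 of the 4 values shown sit.

The compounds shown leave open whether any of these side chains on the shared core differs from another in this assay, and by how much.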